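Swapping the group on a carbonyl carbon of compound 1

A few compounds are considered here, and "the series" means these few. Any claim that something is new, unique, unknown or untested is made for them only; others in the source may bear on it.

In a functional assay on PC-3 cells (Homo sapiens), read by MTT assay, with a stated time of 48 h (a higher number here means a weaker inhibitor, a lower number a stronger inhibitor), compound 1 `CCn1c(C(=O)NCC(OC)OC)ccc1C(CC)(CC)c1ccc(OCC(O)C(C)(C)C)c(C)c1` gives 14600 nM as its result. Compound 3 `CCn1c(C(=O)N(C)CC(=O)O)ccc1C(CC)(CC)c1ccc(OCC(=O)C(C)(C)C)c(C)c1` gives 18400 nM and sits within the usual scatter of compound 1. Compound 2 `CC[C@@H](C)[C@H](NC(=O)c1ccc(C(CC)(CC)c2ccc(OCC(=O)C(C)(C)C)c(C)c2)n1CC)C(=O)O` gives 1600 nM which is clearly lower than both, marking it as the stronger inhibitor of the three.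

Compound 4 `CCn1c(C(=O)Oc2ccc(CCO)cc2)ccc1C(CC)(CC)c1ccc(OCC(O)C(C)(C)C)c(C)c1` keeps the core of compound 1 and changes one place. The change is a group of 10 heavy atoms (8 carbon, 2 oxygen; one six-membered aromatic ring of carbon only) in place of a group of 7 heavy atoms (4 carbon, 1 nitrogen, 2 oxygen; no ring), on a carbonyl carbon and none of the three measured compounds carries a ring in that place.

Going by the values given here, no measured step starts at compound 1 or ends at compound 4. The closest evidence is a 12-fold higher number from compound 2 to compound 3 (1.06 log units; beyond the scatter) and it too swaps a group on a carbonyl carbon. It shows that such a swap can move the number a long way, but it joins two other groups and gives no direction for compound 4. The expected step is modest, a 1.5-fold lower number from compound 1 to compound 4 (0.16 log units; within the scatter) as an estimate, with no shift beyond the scatter foreseen. Compound 4 is estimated at 10000 nM with an expected range from 3000 nM to 30000 nM which is wide enough to allow a large shift either way.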

Compound 4, half-maximal inhibitory concentration: 6300 nM
The estimate for compound 4 lay 1.6-fold (0.20 log units) above the measured number, and the stated range covers the measured number.
By their numbers in this assay, from the lowest: compound 2; then compound 4; then compounds 1 and 3 (each within the scatter of the next).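

In this assay, going by these compounds alone, replacing the (2,2-dimethoxyethyl)amino group on this carbonyl carbon gives a 2.3-fold lower number from compound 1 to compound 4 (0.37 log units; beyond the scatter) as a modest step that lies beyond the scatter, and this is the first measured step that starts from compound 1. It shows that this place accepts a larger group with a six-membered aromatic ring of carbon only and no nitrogen, and that the number falls rather than rises with that swap. The leaving and entering groups have equal counts of hydrogen-bond donors and acceptors and no net charge, so those counts do not separate them, and no measurement here explains why the number moved.

The change adds the ring, removes the nitrogen and enlarges the group all at once, so the compounds shown cannot say which of these matters. A plain phenyl group or a piperidine on the same carbonyl carbon of compound 1 would help to separate those features, and a carboxylic acid there would test whether the result holds for a very different group.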